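A few compounds are considered here, and "the series" means these few. Any claim that something is new, unique, unknown or untested is made for them only; others in the source may bear on it.

Working notes on the series. In a functional assay on DU-145 cells (Homo sapiens) for antiproliferative activity, read by WST assay, with a stated time of 72 h (on this read-out lower numbers stand for an effect already at smaller amounts and higher numbers for an effect only at larger amounts of compound), compound 1 `CCCCCCCC/C=C\c1c(C)c(/C=C\CCCCCCCC)c2[n+](c1C)CCC2` gives 1 uM, and compound 2 `CCCCCCCC/C=C/c1c(C)cc(C)[n+]2c1CCC2` gives 0.6 uM. Among the compounds with values here, these two values lie within the usual scatter of each other, so the numbers so far do not separate compound 2 from compound 1.

The next compound to be read is compound 3 `CCCCCCCC/C=C\c1c(C)cc(C)[n+]2c1CCC2`. The structural change is the two compounds have the same atoms and bonds and differ only in configuration as drawn: 1 of 1 stereo elements differ; a double bond is drawn E in compound 2 and Z in compound 3. Nothing leaves and nothing enters, so the comparison concerns configuration alone.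

Within the data shown here, the series holds no measured pair differing in one place, so no direct guide exists for the size of such a change in this assay. The expectation therefore starts from compound 2 at 0.6 uM, and no step beyond the scatter is expected in either direction. The expected change is a 1.2-fold higher number from compound 2 to compound 3 (0.07 log units; within the scatter), which is an estimate that stays within the scatter. For compound 3 the estimated value is 0.7 uM, with an expected range from 0.3 uM to 1.6 uM.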

Compound 3, concentration for half-maximal effect: 0.2 uM
Estimate against measurement, compound 3: 3.5-fold (0.54 log units) above; the measured number lies below the stated range.
By their numbers in this assay, from the lowest: compound 3; then compounds 2 and 1 (each within the scatter of the next).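

In this assay, within the data shown here, the double bond of the chain gives the first single change that moves the number beyond the scatter, with a 3.0-fold lower number from compound 2 to compound 3 (0.48 log units; beyond the scatter). For this pair, the lower number goes with the Z form, and the step can be assigned to the configuration of this double bond alone: the fact that compounds 2 and 3 differ only in the configuration as drawn. With the Z configuration present in both compounds, hydrogen in place of dec-1-en-1-yl on an aromatic carbon gives a 5.0-fold lower number from compound 1 to compound 3 (0.70 log units; beyond the scatter), so the extra chain is not needed for activity on these cells, and its removal goes with the lower number.

The compounds shown leave open whether the preference for the Z form extends beyond this single pair, for instance to a shorter chain, while a saturated decyl chain would show whether the double bond itself is needed at all. They also leave open whether a polar end on the chain, such as an amine or a carboxylic acid, would be tolerated, and the reason for the effect of configuration remains unresolved.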